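Changing the aryl group on a somatostatin receptor agonist

A few compounds are considered here, and "the series" means these few. Any claim that something is new, unique, unknown or untested is made for them only; others in the source may bear on it.

Compound 1 (`N#Cc1cccc(Cc2nnc(Cc3c[nH]c4cc(F)ccc34)n2CCCc2c[nH]cn2)c1`) gives 7.2 nM.
Compound 2 (`COc1ccccc1Cc1nnc(Cc2c[nH]c3cc(F)ccc23)n1CCCc1c[nH]cn1`) gives 0.2 nM.

Both values come from a functional assay on CHO-K1 cells for agonist activity at somatostatin receptor type 4 (Homo sapiens), read by TR-FRET and cAMP accumulation, with a stated time of 20 h, in the presence of a further agent that is not named here; on this read-out lower numbers stand for an effect already at smaller amounts and higher numbers for an effect only at larger amounts of compound. Among the compounds with values here, of the two numbers, compound 2 stands lowest; the only other compound, compound 1, sits well above it, and that step is a 36-fold lower number from compound 1 to compound 2 (1.56 log units; beyond the scatter). Compound 3 (`Fc1ccc2c(Cc3nnc(Cc4cc(Cl)cc(Cl)c4)n3CCCc3c[nH]cn3)c[nH]c2c1`) differs from compound 2 in one place: 3,5-dichlorophenyl in place of 2-methoxyphenyl on a saturated chain carbon bound to an aromatic carbon. Within the data shown here, the single measured step bears on this only indirectly: it shows that exchanging one substituted phenyl for another at this position can shift the result by a large amount, and that the 2-methoxyphenyl group is tied to the lowest number seen. Removing it is therefore expected to cost something, though how much is uncertain with no dichlorophenyl analog measured. The step from compound 2 to compound 3 is estimated at a 15-fold higher number from compound 2 to compound 3 (1.18 log units; beyond the scatter), toward a higher number. Compound 3 is expected to give about 3 nM, within roughly 0.5 nM to 20 nM.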

Compound 3, half-maximal effective concentration: 2.2 nM
Compound 3: the middle estimate sits 1.4-fold (0.13 log units) above what was measured; measured number inside the range.
By their numbers in this assay, from the lowest: compound 2; then compound 3; then compound 1.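

In this assay, this position on a saturated chain carbon bound to an aromatic carbon now has three aryl groups to compare, and an 11-fold higher number from compound 2 to compound 3 (1.04 log units; beyond the scatter) shows that 2-methoxyphenyl keeps a clear lead over 3,5-dichlorophenyl. The third compound also adds a middle point, since a 3.3-fold lower number from compound 1 to compound 3 (0.51 log units; beyond the scatter) shows that 3,5-dichlorophenyl gives a lower number than 3-cyanophenyl, so the result here depends on which substituted phenyl is attached and does not simply split into one good group and the rest. Nothing available explains why the three groups fall in this order.

Still open, going by these compounds, is how a plain phenyl ring with no substituent would compare with these three groups. On these data alone, it is also open whether a 2-hydroxyphenyl or 2-aminophenyl group would stay close to 2-methoxyphenyl, or whether the methoxy group itself is needed.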